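The source may hold more compounds than are shown below. What is called first, only, known or untested is meant among the compounds shown, and "the series" means these compounds.

Of the compounds shown here, three have so far been tested in a functional assay on MCF7 cells (Homo sapiens) for inhibition, read by MTT assay, with a stated time of 48 h, tested at 10 uM; on this read-out higher numbers stand for more inhibition at the one concentration tested (going by the name of the read-out) and lower numbers for less inhibition. Compound 1 `COc1cc2ccc(=O)oc2cc1OCCCCOc1no[n+]([O-])c1S(=O)(=O)c1ccccc1` gives 84.4%. Compound 2 `COc1cc2cc(NC(C)=O)c(=O)oc2cc1OCCOc1no[n+]([O-])c1S(=O)(=O)c1ccccc1` gives 83.7% in this assay, and compound 3 `COc1cc2cc(NC(C)=O)c(=O)oc2cc1OCCCOc1no[n+]([O-])c1S(=O)(=O)c1ccccc1` gives 88.5% in this assay. Compound 1 stands second highest of these three numbers, but its gap to compound 2 and its gap to compound 3 both lie within the usual scatter of repeated measurements, so the three values cannot really be told apart.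

Compound 4 `COc1cc2cc(NC(C)=O)c(=O)oc2cc1OCCCCOc1no[n+]([O-])c1S(=O)(=O)c1ccccc1` has not yet been measured. It differs from compound 1 in one place: acetamido in place of hydrogen on an aromatic carbon. Compounds 2 and 3 already carry the acetamido group on the shared core, each with a shorter linking chain than compound 1, and their values in this assay sit alongside that of compound 1. Among the compounds with values here, no step between measured compounds is available that isolates what adding acetamido does, so any expectation rests on this resemblance alone.

Adding the acetamido group is expected to produce a number 1.6 percentage points higher from compound 1 to compound 4 (within the scatter), a step not beyond the scatter in either direction. Compound 4 is estimated to give 86% in this assay, with a range from 78% to 93%.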

Compound 4, a percentage reported as inhibition, at one concentration (the size of the read-out at that concentration, not a potency): 80.4%
For compound 4 the middle estimate is 5.6 percentage points above the measured one, within the range that was stated.
By their numbers in this assay, from the lowest: compounds 4, 2, 1 and 3 (each within the scatter of the next).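

Within the data shown here, compound 1 and compound 4 form the first pair in this set that isolates the acetamido group, since the linking chain and the rest of the shared core stay the same. In this assay, placing acetamido in place of hydrogen on an aromatic carbon, two atoms from the ring oxygen, gives a number 4 percentage points lower from compound 1 to compound 4 (within the scatter), so at this one concentration and with this chain, the position accepts the larger group without a change that can be told from the scatter. Nothing measured here bears on what lies behind this small step.

Still open, from the compounds shown here alone, is whether a smaller or charged group at the same position, such as an amine or a carboxylic acid, would shift the number beyond the scatter, or whether a longer chain carrying the same acetamido group would do so. A single concentration also gives no potency, so compound 1 and compound 4 could still differ at lower concentrations, where a gap hidden at this level of inhibition might appear.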